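This account rests on a few compounds, and the source may have more. Where it says the series, first, only, none or still open, it means among the compounds named here.

In a functional assay on L1210 cells (Mus musculus) for inhibition (a lower number here means a stronger inhibitor, a higher number a weaker inhibitor), compound 1 (`O=C1/C(=C/c2cccc(Br)c2)Cc2ccccc21`) gives 43300 nM and compound 2 (`Cc1cccc(/C=C2\CCc3ccccc3C2=O)c1`) gives 73200 nM. Compound 3 (`O=C1/C(=C/c2cccc(Cl)c2)CCCc2ccccc21`) reads 52300 nM and stands within the scatter of both compound 1 and compound 2, so the three values fall into one group with no order among them.

The next entry, compound 4 (`O=C1/C(=C/c2cccc([N+](=O)[O-])c2)CCCc2ccccc21`), has not yet been measured. It carries nitro in place of chloro on an aromatic carbon of a six-membered aromatic ring of carbon only, meta to a large group: nitro in place of chloro on an aromatic carbon.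

Within the data shown here, no two measured compounds differ in one place only, so the series gives no direct reading of this exchange. Among the measured compounds shown here, the only guide is indirect: the measured compounds differ from one another in more than one place, yet compound 3 at 52300 nM stays within the scatter of the other two. On that basis, no step beyond the scatter is expected in this assay, and neither direction is favoured. The estimate amounts to a 1.0-fold lower number from compound 3 to compound 4 (0.02 log units; within the scatter), a step expected to stay within the scatter. For compound 4 the estimated value is 50000 nM, with an expected range from 22000 nM to 110000 nM.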

Compound 4, half-maximal inhibitory concentration: 48800 nM
Beside the measured number, compound 4's estimate is 1.0-fold (0.01 log units) above it; low and high end bracket the measured number.
By their numbers in this assay, from the lowest: compounds 1, 4, 3 and 2 (each within the scatter of the next).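

In this assay the series now has its first exchange at a single place, with a 1.1-fold lower number from compound 3 to compound 4 (0.03 log units; within the scatter) for nitro in place of chloro on an aromatic carbon, meta to a large group. Among these compounds, at this position, going from chloro with 1 heavy atom and 0 hydrogen-bond acceptors to nitro with 3 heavy atoms and 2 hydrogen-bond acceptors leaves the reading within the scatter, so this exchange produces no detectable step here. No measurement is at hand that explains this reading.

Going by these compounds, whether the reading also stays within the scatter with other groups at this place, such as an amine, a carboxylic acid or a longer alkyl chain, remains open, as does the outcome of the same exchange elsewhere on this aromatic ring. Compound 1 and compound 2 each differ from compound 3 in more than one place, so no single change among them can yet be read, and a one-place comparison would be needed to separate those changes.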